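The source may hold more compounds than are shown below. What is called first, only, known or untested is meant among the compounds shown, and "the series" means these compounds.

Three compounds built on one shared core have been run in an ADME assay on PC-3 cells (Homo sapiens) for cytotoxicity, read by WST assay, tested at 100 uM; on this read-out lower numbers stand for less inhibition and higher numbers for more inhibition at the one concentration tested (going by the name of the read-out). Compound 1 `CC(C)(C)OC(=O)c1cccc(NC(=O)C2CCCN(C(=O)c3cc(C(F)(F)F)cc(C(F)(F)F)c3)C2)c1` gives 0%. Compound 2 `CSc1cccc(NC(=O)C2CCCN(C(=O)c3cc(C(F)(F)F)cc(C(F)(F)F)c3)C2)c1` gives 0%, and compound 3 `CCc1cccc(NC(=O)C2CCCN(C(=O)c3cc(C(F)(F)F)cc(C(F)(F)F)c3)C2)c1` gives 0%. The three steps among them are flat: no change at the digits printed from compound 1 to compound 2 (within the scatter), no change at the digits printed from compound 1 to compound 3 (within the scatter) and no change at the digits printed from compound 2 to compound 3 (within the scatter). Compound 3 thus stands level with compounds 1 and 2 at the digits shown, with compound 1 its nearest neighbour and compound 2 its furthest, both gaps lying within the scatter.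

Compound 4 `O=C(c1ccccc1)c1cccc(NC(=O)C2CCCN(C(=O)c3cc(C(F)(F)F)cc(C(F)(F)F)c3)C2)c1` has not yet been measured in this assay. It differs from compound 3 in one place: benzoyl in place of ethyl on an aromatic carbon. The group that enters carries a six-membered aromatic ring of carbon only, one double bond outside aromatic rings and one hydrogen-bond acceptor, where the ethyl it replaces carried none.

All three measured steps swap one group at this same aromatic carbon, and none of them moved the read-out beyond the scatter. Benzoyl is unlike any of the three groups tried there, so the precedent is only partial, yet nothing measured points to a rise. The expected step is therefore no change at the digits printed from compound 3 to compound 4 (within the scatter), none beyond the scatter. Compound 4 is estimated at 0%, with a range from 0% to 15%.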

Compound 4, a percentage reported as inhibition, at one concentration (the size of the read-out at that concentration, not a potency): 0%
Beside the measured number, compound 4's estimate shows no gap at the digits printed; low and high end bracket the measured number.
By their numbers in this assay, from the lowest: compounds 1, 2, 3 and 4 (each within the scatter of the next).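

In this assay benzoyl, the only group shown at this aromatic carbon that carries a six-membered aromatic ring of carbon only, leaves the read-out flat, with benzoyl in place of ethyl giving no change at the digits printed from compound 3 to compound 4 (within the scatter) and benzoyl in place of methylsulfanyl giving no change at the digits printed from compound 2 to compound 4 (within the scatter) at this place. The same holds at the carbonyl carbon, where phenyl in place of tert-butoxy gives no change at the digits printed from compound 1 to compound 4 (within the scatter) on the otherwise unchanged compound, so the flat read-out now extends from a group of 2 heavy atoms without a ring to a group of 8 heavy atoms with one. No measurement offers an explanation for this flat behaviour.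

Since the four compounds shown sit level in this assay, they do not tell whether any group at this aromatic carbon can raise the read-out, and a carboxylic acid, an amine or a hydroxyl there remains an open case. They also leave open whether a change away from this position, such as replacing the two trifluoromethyl groups with chlorine atoms, would move the read-out at all.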